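Shortening the Acyl Chain on the Shared Core

The source may report more compounds than this note shows. Statements on the series, on what has been measured and on what is new or still open speak of the compounds shown alone.

Compound 1 `NCCNc1cc(N2CCN(c3ccccc3)CC2)nc2ccccc12`: 20800 nM
Compound 2 `CC(C)C(=O)N1CCN(c2cc(NCCN)c3ccccc3n2)CC1`: > 100000 nM

In an ADME assay on HEp-2 cells (Homo sapiens) for cytotoxicity, read by CCK-8 assay, with a stated time of 6 days (a lower number here means that less compound is tolerated, a higher number that more compound is tolerated), compound 1 gives 20800 nM. Compound 2 sits at the limit of > 100000 nM in this assay, at which 1 of the 2 values shown sits; its value is a limit of the assay, not a number. Going by the values given here, the only measured step, an at least 4.8-fold higher number from compound 1 to compound 2 (0.68 log units; beyond the scatter), swapped the group on the ring amine nitrogen. Compound 3 `CC(=O)N1CCN(c2cc(NCCN)c3ccccc3n2)CC1` is not yet measured; it differs from compound 2 in methyl in place of isopropyl on a carbonyl carbon. Among the compounds with values here, this change lies on the carbonyl carbon, a place no measured step touches, so the step from compound 1 to compound 2 bears on it only loosely, and it gives no guide to direction. With compound 2 already at the limit, no step beyond the scatter is expected in this assay, though a number somewhat under the limit cannot be excluded. Compound 3 is therefore estimated at 100000 nM (range 40000 nM to 250000 nM), which means an expected a number no higher from compound 2 to compound 3 (the limit leaves the size open).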

Compound 3, half-maximal cytotoxic concentration: > 100000 nM
Compound 3 was reported as a limit; the forecaster's own chance of this, stated with the estimate: 65%; the middle value sits exactly at the limit.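

In this assay compound 3 gives > 100000 nM, and this is a limit of the assay, not a number. Acetyl in place of phenyl on an amine nitrogen in a ring gives an at least 4.8-fold higher number from compound 1 to compound 3 (0.68 log units; beyond the scatter), so both the acetyl and the isopropylcarbonyl compounds now stand clear of compound 1, while the step between compound 2 and compound 3 cannot be read, as both values are limits. Going from isopropyl to methyl on the carbonyl carbon thus brings no readable drop, and the read-out for this pair stays at the top of its range: the limit of > 100000 nM in this assay, at which 2 of the 3 values shown sit.

From the compounds shown here alone, how far past the limit compound 2 and compound 3 each lie remains unknown, so the two cannot be ranked. Going by these compounds, whether a longer chain or an amine on that carbonyl carbon would bring the number back under the limit also stays open.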